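Chloro gives way to 4-methylpiperazin-1-yl on the nitro series

The compounds below may be only part of what the source reports. "The series", "measured", "known", "first", "only" and "open" are said of these compounds alone.

For the measured compounds named here, in a functional assay on KB cells (Homo sapiens) for cytotoxicity, read by MTT assay, with a stated time of 48 h (a lower number here means a stronger inhibitor, a higher number a weaker inhibitor), compound 2 (`CCn1cc(-c2nc3ccc([N+](=O)[O-])cc3o2)c(=O)c2cc(F)c(Cl)cc21`) gives 500 nM as the lower of the two numbers so far. Compound 1 (`CCn1cc(-c2nc3ccccc3o2)c(=O)c2cc(F)c(N3CCN(C)CC3)cc21`) gives 87400 nM and differs from compound 2 in two places: it has 4-methylpiperazin-1-yl in place of chloro, and it lacks the nitro group. Going by the values given here, no measured pair separates these two changes. Compound 3 (`CCn1cc(-c2nc3ccc([N+](=O)[O-])cc3o2)c(=O)c2cc(F)c(N3CCN(C)CC3)cc21`) keeps the nitro group and has 4-methylpiperazin-1-yl in place of chloro on an aromatic carbon, ortho to a fluoro group (4-methylpiperazin-1-yl in place of chloro on an aromatic carbon). The estimated step of a 10-fold higher number from compound 2 to compound 3 (1.00 log units; beyond the scatter) is expected to mean weaker inhibition, beyond the scatter. This expectation rests on compound 1, which carries the same group and gives 87400 nM without the nitro group. In this assay compound 3 is estimated at 5000 nM with an expected range from 700 nM up to 35000 nM as its upper end.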

Compound 3, half-maximal inhibitory concentration: 40300 nM
Estimate against measurement, compound 3: 8.1-fold (0.91 log units) below, outside the stated range (above it).
By their numbers in this assay, from the lowest: compound 2; then compound 3; then compound 1.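

In this assay the two changes can now be read apart. With the nitro group held, 4-methylpiperazin-1-yl in place of chloro gives the large step (an 81-fold higher number from compound 2 to compound 3 (1.91 log units; beyond the scatter)), while with 4-methylpiperazin-1-yl held, nitro in place of hydrogen gives only a modest one (a 2.2-fold lower number from compound 1 to compound 3 (0.34 log units; beyond the scatter)). At this position, ortho to a fluoro group, the exchange of chloro for 4-methylpiperazin-1-yl is therefore the larger of the two steps, and nothing measured here accounts for its size.

As far as these compounds go, it remains open where an unsubstituted piperazine, a morpholine or a simple primary amine would stand relative to chloro at this position. From the compounds shown here alone, it also remains open whether nitro in place of hydrogen would give a step of similar size with chloro on the core.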